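This account rests on a few compounds, and the source may have more. Where it says the series, first, only, none or still open, it means among the compounds named here.

Compound 1 `C=C1CC[C@@H]2[C@](C)(COC(C)=O)[C@H](OC(C)=O)CC[C@@]2(C)[C@H]1CC(Nc1ccc(S(=O)(=O)Nc2ccc(Cl)nn2)cc1)C1=CCOC1=O`: in a functional assay on MOLT-4 cells (Homo sapiens) for inhibition, read by sulforhodamine B assay, with a stated time of 48 h (a higher number here means a weaker inhibitor of growth, a lower number a stronger inhibitor of growth), compound 1 gives > 100000 nM, which is a limit of the assay. Compound 2 `C=C1CC[C@@H]2[C@](C)(COC(C)=O)[C@H](OC(C)=O)CC[C@@]2(C)[C@H]1CC(Nc1ccc(S(=O)(=O)Nc2cc(C)on2)cc1)C1=CCOC1=O`: compound 2 gives 6390 nM. Compound 3 `C=C1CC[C@@H]2[C@](C)(COC(C)=O)[C@H](OC(C)=O)CC[C@@]2(C)[C@H]1CC(Nc1ccc(S(=O)(=O)Nc2nccc(C)n2)cc1)C1=CCOC1=O`: compound 3 gives 17900 nM.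

Compound 3 carries the highest of the two numbers, its nearest neighbour being compound 2, with a 2.8-fold higher number from compound 2 to compound 3 (0.45 log units; beyond the scatter). Compound 4 `C=C1CC[C@@H]2[C@](C)(COC(C)=O)[C@H](OC(C)=O)CC[C@@]2(C)[C@H]1CC(Nc1ccc(S(=O)(=O)Nc2ncccn2)cc1)C1=CCOC1=O` differs from compound 3 by hydrogen in place of methyl on an aromatic carbon. Within the data shown here, no measured step removes only a methyl; the measured steps exchange the whole heteroaryl on the sulfonamide nitrogen, namely an at least 15-fold lower number from compound 1 to compound 2 (1.19 log units; beyond the scatter), an at least 5.5-fold lower number from compound 1 to compound 3 (0.74 log units; beyond the scatter) and a 2.8-fold higher number from compound 2 to compound 3 (0.45 log units; beyond the scatter), the first two being bounded by the limit of > 100000 nM in this assay, at which 1 of the 3 values shown sits. A change of one carbon within the same ring is expected to give a step within the scatter, in no clear direction. Compound 4 is therefore estimated at 20000 nM, between 8000 nM and 50000 nM, an expected step of a 1.1-fold higher number from compound 3 to compound 4 (0.05 log units; within the scatter).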

Compound 4, concentration for total growth inhibition: 8370 nM
Compound 4: middle estimate off by 2.4-fold (0.38 log units), on the high side, within the range that was stated.
By their numbers in this assay, from the lowest: compounds 2 and 4 (each within the scatter of the next); then compound 3. At a limit, above all of these: compound 1.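

In this assay, the methyl on the pyrimidine is not silent: hydrogen in its place, on the aromatic carbon next to the ring nitrogen, gives a modest step (a 2.1-fold lower number from compound 3 to compound 4 (0.33 log units; beyond the scatter)). Without that methyl, the pyrimidin-2-yl group of compound 4 stands level with the 5-methyl-1,2-oxazol-3-yl group (a 1.3-fold higher number from compound 2 to compound 4 (0.12 log units; within the scatter)). The step from the 6-chloropyridazin-3-yl group (an at least 11-fold lower number from compound 1 to compound 4 (1.07 log units; beyond the scatter)) is only a bound: (the limit of > 100000 nM in this assay, at which 1 of the 4 values shown sits).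

Open, as far as these compounds go, is how an amino, methoxy or ethyl group at this carbon compares with hydrogen and methyl. Also open, from the compounds shown here alone, is whether removing the methyl from the 5-methyl-1,2-oxazol-3-yl group moves the number the same way.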